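This account rests on a few compounds, and the source may have more. Where it says the series, first, only, none or still open, it means among the compounds named here.

Compound 1, `COc1cc2cc(Oc3ccc(NC(=O)Nc4ccccc4)cc3)c(C)nc2cc1OC`, gives 69.1%.
Compound 2, `COc1cc2cc(Oc3ccc(NC(=O)Nc4ccc(C)cc4)cc3)c(C)nc2cc1OC`, gives 108%.

In a functional assay on NCI-H460 cells (Homo sapiens) for inhibition, read by sulforhodamine B assay, with a stated time of 48 h, tested at 10 uM (on this read-out lower numbers stand for a stronger effect and higher numbers for a weaker effect at the one concentration tested), compound 2 stands highest of the two numbers, the nearest being compound 1. Going by the values given here, the only measured step, a number 38.9 percentage points higher from compound 1 to compound 2 (beyond the scatter), concerns the same aromatic carbon that changes now. Compound 3, `COc1cc2cc(Oc3ccc(NC(=O)Nc4ccc(C(F)(F)F)cc4)cc3)c(C)nc2cc1OC`, differs from compound 2 by trifluoromethyl in place of methyl on an aromatic carbon. Among the compounds with values here, no measured step shows a trifluoromethyl replacing a methyl, so the expectation is a step within the scatter in this assay, the estimated step being a number 8 percentage points lower from compound 2 to compound 3 (within the scatter). Compound 3 is therefore expected to give 100%, estimated within 75% to 125%.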

Compound 3, a percentage reported as activity, at one concentration (the size of the read-out at that concentration, not a potency): 42.8%
Compound 3: middle estimate off by 57.2 percentage points, on the high side; measured number below the stated range.
By their numbers in this assay, from the lowest: compound 3; then compound 1; then compound 2.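

Trifluoromethyl on this aromatic carbon, para to a large group, brings a number 65.2 percentage points lower from compound 2 to compound 3 (beyond the scatter) and a number 26.3 percentage points lower from compound 1 to compound 3 (beyond the scatter) in this assay and so moves the number the opposite way from methyl. Across compound 1, compound 2 and compound 3, the outcome therefore depends on which group enters, not merely on hydrogen being replaced. Nothing at hand explains this divergence between the two groups. On these data alone, whether a chlorine atom, a methoxy group or an amine at this carbon would follow trifluoromethyl or methyl stays open. So does whether trifluoromethyl elsewhere on this ring would give a similar number.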